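Chloro on the fused ring of compound 3

A few compounds are considered here, and "the series" means these few. Any claim that something is new, unique, unknown or untested is made for them only; others in the source may bear on it.

Measured compounds in a functional assay (aorta) with Oryctolagus cuniculus as the target; a lower number here means tighter binding, a higher number weaker binding:
compound 1 `CCCCc1nc2ncccc2n1Cc1cc(Cl)c(O)c(Cl)c1`, 398 nM
compound 2 `CCCc1nc2ncccc2n1Cc1cc(Cl)c(O)c(Cl)c1`, 794 nM
compound 3 `CCCc1nc2cccnc2n1Cc1ccc(-c2ccccc2C(=O)O)cc1`, 39.8 nM

Compound 3 stands lowest of the three in this assay; the gaps to compound 1 and compound 2 are both beyond the scatter. Compound 4 `CCCc1nc2c(Cl)ccnc2n1Cc1ccc(-c2ccccc2C(=O)O)cc1` is the next step: chloro in place of hydrogen on an aromatic carbon. The only measured step, a 2.0-fold higher number from compound 1 to compound 2 (0.30 log units; within the scatter), concerns the saturated chain and not the fused ring, so nothing shown bears on a chloro at this position. Among the compounds with values here, with no step to lean on, compound 4 is expected to stay close to compound 3, with a 1.0-fold higher number from compound 3 to compound 4 (0.00 log units; within the scatter) judged as no change beyond the scatter. Compound 4 is therefore estimated at 40 nM in this assay, ranging from 10 nM to 160 nM.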

Compound 4, dissociation constant: 7.94 nM
Beside the measured number, compound 4's estimate is 5.0-fold (0.70 log units) above it; measured number outside the range, below it.
By their numbers in this assay, from the lowest: compound 4; then compound 3; then compounds 1 and 2 (each within the scatter of the next).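

In this assay, chloro in place of hydrogen on this aromatic carbon, opposite the ring nitrogen, gives a 5.0-fold lower number from compound 3 to compound 4 (0.70 log units; beyond the scatter), a modest step. It shows that this position on the fused ring is not silent: a single chlorine here moves the number beyond the scatter, and towards tighter binding. No measurement at hand accounts for the change.

On these data alone, what a fluoro, a methyl or an amine would do on the same carbon stays open. So does whether chloro would give a step of this size with the other groups of compound 1.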